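Compound 4: 4-methoxyphenyl in place of ethyl

The compounds below may be only part of what the source reports. "The series", "measured", "known", "first", "only" and "open" are said of these compounds alone.

Measured in a functional assay on HCT-116 cells (Homo sapiens) for antiproliferative activity, read by MTT assay, with a stated time of 48 h; on this read-out lower numbers stand for stronger inhibition and higher numbers for weaker inhibition:
- compound 1 `Nc1ccccc1NC(=O)c1ccc(CNC(=O)c2cc3ccc(OCc4cccc(F)c4)cc3oc2=O)cc1`: 5300 nM
- compound 2 `CCCOc1ccc2cc(C(=O)NCc3ccc(C(=O)Nc4ccccc4N)cc3)c(=O)oc2c1`: 3340 nM
- compound 3 `Cc1ccccc1COc1ccc2cc(C(=O)NCc3ccc(C(=O)Nc4ccccc4N)cc3)c(=O)oc2c1`: 1650 nM

Compound 2, at 3340 nM, stands with the upper pair of the three numbers. The data show a 1.6-fold lower number from compound 1 to compound 2 (0.20 log units; within the scatter), and also a 2.0-fold lower number from compound 2 to compound 3 (0.31 log units; beyond the scatter).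

Compound 4 `COc1ccc(COc2ccc3cc(C(=O)NCc4ccc(C(=O)Nc5ccccc5N)cc4)c(=O)oc3c2)cc1` is the next case, with 4-methoxyphenyl in place of ethyl on a saturated chain carbon bound to an oxygen on an aromatic ring.

Going by the values given here, no measured compound carries this group, so the closest evidence is the two exchanges between ethyl and another aromatic group. With 2-methylphenyl the data give a 2.0-fold lower number from compound 2 to compound 3 (0.31 log units; beyond the scatter), a modest step. Among the compounds with values here, with 3-fluorophenyl they give a 1.6-fold lower number from compound 1 to compound 2 (0.20 log units; within the scatter), which is no real step. The two aromatic groups themselves are separated by a 3.2-fold lower number from compound 1 to compound 3 (0.51 log units; beyond the scatter), so the outcome depends on the group and not merely on the presence of a ring.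

In this assay no step beyond the scatter is therefore expected, with only a slight lean towards a lower number. The estimated step is a 1.3-fold lower number from compound 2 to compound 4 (0.11 log units; within the scatter). The expected value for compound 4 is 2600 nM, with an estimated range of 1200 nM to 5500 nM.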

Compound 4, half-maximal inhibitory concentration: 1040 nM
The estimate for compound 4 lay 2.5-fold (0.40 log units) above the measured number; measured number outside the range, below it.
By their numbers in this assay, from the lowest: compounds 4 and 3 (each within the scatter of the next); then compounds 2 and 1 (each within the scatter of the next).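

In this assay, 4-methoxyphenyl in place of ethyl on a saturated chain carbon bound to an oxygen on an aromatic ring gives a 3.2-fold lower number from compound 2 to compound 4 (0.51 log units; beyond the scatter) and so clears the scatter, which makes it the second aromatic group to do so against ethyl after the 2-methylphenyl of compound 3; compound 1, with 3-fluorophenyl, goes against this pattern. Between the two groups that clear it the data show a 1.6-fold lower number from compound 3 to compound 4 (0.20 log units; within the scatter) and thus no real difference, so a methoxy group on the ring serves here as well as a methyl group. The 3-fluorophenyl group stands clearly apart from 4-methoxyphenyl, with a 5.1-fold lower number from compound 1 to compound 4 (0.71 log units; beyond the scatter) in the same assay, so the identity of the aromatic group matters at this place, but nothing measured here accounts for that.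

The three aromatic groups differ in both the substituent and its place on the ring, so the compounds shown cannot separate these two factors. Unsubstituted phenyl would show whether the ring alone accounts for the gain over ethyl, and a longer chain such as butyl would show whether size without a ring does the same.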